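Imidazolyl in Place of Dimethylamino on the Hydrazone Aryl Ring

This account rests on a few compounds, and the source may have more. Where it says the series, first, only, none or still open, it means among the compounds named here.

In an assay on CHO-K1 cells for displacement of a labelled ligand from adenosine receptor A1 (Homo sapiens), read by scintillation counting, with a stated time of 60 min, tested at 1 uM (on this read-out higher numbers stand for more inhibition at the one concentration tested (going by the name of the read-out) and lower numbers for less inhibition), compound 3 `CN(C)c1ccc(/C=N/Nc2nc(N)c3ncn([C@@H]4O[C@H](CO)[C@@H](O)[C@H]4O)c3n2)cc1` gives 0%. Compound 1 `CSCC/C=N/Nc1nc(N)c2ncn([C@@H]3O[C@H](CO)[C@@H](O)[C@H]3O)c2n1` gives 0% and compound 2 `CCCOc1ccc(/C=N/Nc2nc(N)c3ncn([C@@H]4O[C@H](CO)[C@@H](O)[C@H]4O)c3n2)cc1` gives 7%. The step of no change at the digits printed from compound 1 to compound 3 (within the scatter) and the step of a number 7 percentage points lower from compound 2 to compound 3 (within the scatter) leave compound 3 level with compound 1, the two together the lowest of the three numbers, all of them within the scatter of one another. Compound 4 `Nc1nc(N/N=C/c2ccc(-n3ccnc3)cc2)nc2c1ncn2[C@@H]1O[C@H](CO)[C@@H](O)[C@H]1O` differs from compound 3 in one place: 1H-imidazol-1-yl in place of dimethylamino on an aromatic carbon. The measured steps that bear on this are the exchanges of the group on the carbon with a double bond to nitrogen, a number 7 percentage points higher from compound 1 to compound 2 (within the scatter), and the exchange of one substituent for another on the aromatic carbon, a number 7 percentage points lower from compound 2 to compound 3 (within the scatter); both lie within the scatter. With every change tried so far leaving the read-out unmoved, no step beyond the scatter is expected, and for compound 4 the change is estimated as a number 3 percentage points higher from compound 3 to compound 4 (within the scatter). Compound 4 is therefore expected to give 3%, with a range from -6% to 15%.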

Compound 4, a percentage reported as inhibition, at one concentration (the size of the read-out at that concentration, not a potency): 0%
Estimate against measurement, compound 4: 3 percentage points above; measured number inside the range.
By their numbers in this assay, from the lowest: compounds 1, 3, 4 and 2 (each within the scatter of the next).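

In this assay, the exchange on this aromatic carbon now extends to a ring: 1H-imidazol-1-yl in place of dimethylamino gives no change at the digits printed from compound 3 to compound 4 (within the scatter) and in place of propoxy gives a number 7 percentage points lower from compound 2 to compound 4 (within the scatter), so a five-membered aromatic ring here separates from neither open-chain group. Taking the whole 4-(1H-imidazol-1-yl)phenyl group against 2-(methylsulfanyl)ethyl on the carbon with a double bond to nitrogen gives no change at the digits printed from compound 1 to compound 4 (within the scatter), which adds an aromatic ring with this substituent to the groups that leave the read-out within the scatter. No evidence is available to account for this result.

Going by these compounds, all four compounds lie within the scatter of one another, so whether any group on this aromatic carbon can move the read-out stays open. A primary amine, a carboxylic acid or an alkoxy chain longer than propoxy at this place could still test that.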